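Anilide variation on a shared core: fluoro to chloro swap

A few compounds are considered here, and "the series" means these few. Any claim that something is new, unique, unknown or untested is made for them only; others in the source may bear on it.

Measured so far in a functional assay on U-937 cells (Homo sapiens) for antiproliferative activity, read by CCK-8 assay, with a stated time of 24 h; a lower number here means a stronger inhibitor, a higher number a weaker inhibitor:
- Compound 1, `Cc1ccc(NC(=O)c2cccc(C(F)(F)F)c2)cc1-n1cc(-c2cnc3cccnn23)cn1`: compound 1 gives 13700 nM.
- Compound 2, `Cc1ccc(NC(=O)c2ccc(F)cc2)cc1-n1cc(-c2cnc3cccnn23)cn1`: compound 2 gives only the limit of the assay, > 20000 nM.

Both measured compounds sit at the weak end of this assay. Compound 1 reads as a weak inhibitor. Going by the values given here, for compound 2 no number is known, only that its value lies at the limit (the limit of > 20000 nM in this assay, at which 1 of the 2 values shown sits). Among the compounds with values here, the one measured step, an at least 1.4-fold higher number from compound 1 to compound 2 (0.16 log units; that floor lies within the scatter), is therefore a floor that lies within the scatter and does not settle whether the two anilide groups differ at all.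

Compound 3, `Cc1ccc(NC(=O)c2cccc(Cl)c2)cc1-n1cc(-c2cnc3cccnn23)cn1`, differs from compound 2 by 3-chlorophenyl in place of 4-fluorophenyl on a carbonyl carbon. Within the data shown here, no measured step covers this exact change. Among the measured compounds shown here, the only guide is that compound 1, which carries a substituent on the same phenyl position as the entering 3-chlorophenyl, gives a number rather than a limit, while compound 2 gives a limit; the gap between them is within scatter. No size of step beyond the scatter is therefore expected, in either direction, and the estimate stays near the weak range of both measured compounds.

Compound 3 is expected to give 15000 nM, with a range from 6000 nM to 40000 nM. This estimate means an expected step of an at least 1.3-fold lower number from compound 2 to compound 3 (0.12 log units; that floor lies within the scatter).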

Compound 3, half-maximal inhibitory concentration: > 20000 nM
Compound 3: no number, only a limit; the forecaster's own chance of this, stated with the estimate: 35%; at least 1.3-fold (0.12 log units) between middle value and limit.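

Compound 3 gives only a limit in this assay, as compound 2 does, so neither the 4-fluorophenyl nor the 3-chlorophenyl on the carbonyl carbon yields a number, and the step between these two compounds cannot be read. Chloro in place of trifluoromethyl on an aromatic carbon gives an at least 1.4-fold higher number from compound 1 to compound 3 (0.16 log units; that floor lies within the scatter), a floor that does not settle whether the two groups differ at all. What is new is that a second anilide reaches the limit, leaving compound 1 as the only compound shown with a number, and limits now make up most of the series: the limit of > 20000 nM in this assay, at which 2 of the 3 values shown sit.

From the compounds shown here alone, how far compound 2 and compound 3 lie past the limit remains open, and with it any order among the three anilides. Also open, going by these compounds, is whether an amine or a carboxylic acid in place of the chloro on the aromatic carbon would bring the shared core out of the weak end of this assay.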